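This account rests on a few compounds, and the source may have more. Where it says the series, first, only, none or still open, it means among the compounds named here.

Three compounds share one core and differ only in the ring that hangs from it. In an assay on isolated protein for inhibition of high affinity nerve growth factor receptor (Homo sapiens), read by 33P incorporation (on this read-out lower numbers stand for stronger inhibition and higher numbers for weaker inhibition), compound 1 `Nc1cccc(-c2cnc3[nH]cc(-c4ccncc4)c3c2)c1` gives 42.7 nM. Compound 2 `Nc1ccc(-c2cnc3[nH]cc(-c4ccncc4)c3c2)cc1` gives 25 nM in this assay, and compound 3 `CS(=O)(=O)Nc1cc(N)cc(-c2cnc3[nH]cc(-c4ccncc4)c3c2)c1` gives 33.8 nM in this assay. Compound 2 has the lowest of the three numbers, yet the step of a 1.7-fold lower number from compound 1 to compound 2 (0.23 log units; within the scatter) and the step of a 1.3-fold lower number from compound 1 to compound 3 (0.10 log units; within the scatter) both lie within the scatter, so the three compounds cannot be told apart on these figures.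

Compound 4 `Nc1cncc(-c2cnc3[nH]cc(-c4ccncc4)c3c2)c1` is not yet measured. The change from compound 2 is 5-aminopyridin-3-yl in place of 4-aminophenyl on an aromatic carbon. Neither measured step swaps a ring carbon for a ring nitrogen: one moves the amino group on the same ring, the other adds a methanesulfonamido group. Both stayed within the scatter, so the nearest evidence points to a small effect, and the direction of this new change is open. For compound 4 the expected value in this assay is estimated at 35 nM, with a range from 12 nM to 110 nM. This estimate corresponds to a step of a 1.4-fold higher number from compound 2 to compound 4 (0.15 log units; within the scatter).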

Compound 4, half-maximal inhibitory concentration: 69.6 nM
Beside the measured number, compound 4's estimate is 2.0-fold (0.30 log units) below it; low and high end bracket the measured number.
By their numbers in this assay, from the lowest: compounds 2, 3, 1 and 4 (each within the scatter of the next, the first and the last beyond it).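

For the compounds shown here, the step of a 2.8-fold higher number from compound 2 to compound 4 (0.44 log units; beyond the scatter) is the first at this position to pass beyond the scatter, a modest loss of inhibition on moving from the 4-aminophenyl ring to the 5-aminopyridin-3-yl ring. The step of a 1.6-fold higher number from compound 1 to compound 4 (0.21 log units; within the scatter) stays within the scatter, and it is the cleaner comparison for the ring nitrogen, since the 3-aminophenyl ring of compound 1 differs from the ring of compound 4 only by that atom. Compound 2 differs from compound 4 in both the ring atom and where the amino group sits, and nothing measured here explains the step.

It remains open whether the amino group matters at all, since no ring carrying a hydroxyl or methoxy group in its place is shown. Also open, from the compounds shown here alone, is how a methanesulfonamido group, as on compound 3, would behave on the pyridine ring.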